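Nitro on the fused ring of compound 1: expected effect

The compounds below may be only part of what the source reports. "The series", "measured", "known", "first", "only" and "open" are said of these compounds alone.

Measured compounds:
- compound 1, `Nc1ccccc1NC(=O)c1ccc(CSC(=S)N2CCc3ccccc32)cc1`, 25.7%
- compound 2, `CC1CCN(C(=S)SCc2ccc(C(=O)Nc3ccccc3N)cc2)CC1`, 32.7%
- compound 3, `CN(Cc1cccnc1)C(=S)SCc1ccc(C(=O)Nc2ccccc2N)cc1`, 39.4%

All three share the same core and differ only in the amine attached to the thiocarbonyl carbon. In a functional assay on A-375 cells (Homo sapiens) for antiproliferative activity, read by CCK-8 assay, with a stated time of 72 h, tested at 2 uM (a lower number here means a weaker effect, a higher number a stronger effect of the compound at the concentration tested), compound 1 gives 25.7%, the lowest of the three numbers. The step of a number 7 percentage points higher from compound 1 to compound 2 (within the scatter) is within the scatter, while a number 13.7 percentage points higher from compound 1 to compound 3 (beyond the scatter) is beyond it; between the two larger amines, a number 6.7 percentage points higher from compound 2 to compound 3 (within the scatter) is within the scatter.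

Compound 4, `Nc1ccccc1NC(=O)c1ccc(CSC(=S)N2CCc3cc([N+](=O)[O-])ccc32)cc1`, keeps the 2,3-dihydro-1H-indol-1-yl group of compound 1 and changes only one thing: nitro in place of hydrogen on an aromatic carbon. Among the measured compounds shown here, none of the measured steps touches a substituent on that fused ring; each of them swaps the whole amine instead. For the measured compounds named here, there is therefore no measured step that bears directly on this change, and the measured steps themselves are small to modest. With nothing pointing either way, no step beyond the scatter is expected in this assay for compound 4, and the expected change a number 1.3 percentage points higher from compound 1 to compound 4 (within the scatter) is set close to zero. The estimate for compound 4 is 27%, with a range from 13% to 42%.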

Compound 4, a percentage reported as inhibition, at one concentration (the size of the read-out at that concentration, not a potency): 16.9%
The estimate for compound 4 lay 10.1 percentage points above the measured number, within the range that was stated.
By their numbers in this assay, from the lowest: compounds 4, 1, 2 and 3 (each within the scatter of the next, the first and the last beyond it).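

Among the compounds shown here, with the nitro group on the fused ring, this assay shows a number 8.8 percentage points lower from compound 1 to compound 4 (within the scatter), which is the first reading of a substituent on this ring rather than a swap of the whole amine. At the single concentration tested, then, adding nitro in place of hydrogen on this aromatic carbon, meta to a fused ring and para to a fused ring, does not clearly separate compound 4 from compound 1. No measurement is available that could explain this small step, so the result describes only the effect on the read-out and not its origin.

From the compounds shown here alone, it remains open whether an amino group or a methoxy group on the same aromatic carbon would give a step beyond the scatter, or whether nitro at another carbon of the fused ring would read differently. Because each compound is read at only one concentration, the comparison of compound 1 with compound 4 also leaves open whether their potencies would match across a full range of concentrations.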